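The compounds below may be only part of what the source reports. "The series", "measured", "known", "first", "only" and "open" are said of these compounds alone.

Measured so far in a functional assay on CCRF-CEM cells (Homo sapiens) for inhibition, read by MTT assay, with a stated time of 2 days, tested at 10 uM; a higher number here means more inhibition at the concentration tested (going by the name of the read-out), a lower number less inhibition:
compound 1 `COc1ccc(OC)c(-c2cn(-c3ccc(O)c(C(=O)Nc4cccc(C(F)(F)F)c4)c3)nn2)c1` gives 15%
compound 2 `COc1ccc(-c2cn(-c3ccc(O)c(C(=O)O)c3)nn2)cc1` gives 9%

Compound 2 stands at the lower of the two numbers, though its gap to compound 1 lies within the usual scatter, so neither is set apart. Compound 3 `COc1ccc(-c2cn(-c3ccc(O)c(C(=O)Nc4cccc(C(F)(F)F)c4)c3)nn2)cc1` is not yet measured; its change from compound 2 is (3-(trifluoromethyl)phenyl)amino in place of hydroxy on a carbonyl carbon. Compound 1 carries the same (3-(trifluoromethyl)phenyl)amino group and gives 15%, so for compound 3 the step of a number 5 percentage points higher from compound 2 to compound 3 (within the scatter) is expected to be small and upward, not beyond the scatter. Compound 3 is estimated at 14%, within 3% to 30%.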

Compound 3, a percentage reported as inhibition, at one concentration (the size of the read-out at that concentration, not a potency): 12%
For compound 3 the middle estimate is 2 percentage points above the measured one; the range from low to high includes it.
By their numbers in this assay, from the lowest: compounds 2, 3 and 1 (each within the scatter of the next).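

In this assay the exchange of hydroxy for (3-(trifluoromethyl)phenyl)amino on the carbonyl carbon gives a number 3 percentage points higher from compound 2 to compound 3 (within the scatter) and so does not separate the two groups at this position. The exchange of 2,5-dimethoxyphenyl for 4-methoxyphenyl on the aromatic carbon gives a number 3 percentage points lower from compound 1 to compound 3 (within the scatter) and leaves that place equally unresolved at the concentration tested. Nothing available explains these small steps.

Still open, as far as these compounds go, is whether a methyl ester or a benzylamino group on the carbonyl carbon, or 4-chlorophenyl in place of 4-methoxyphenyl, would give a step beyond the scatter.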